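This account rests on a few compounds, and the source may have more. Where it says the series, first, only, none or still open, it means among the compounds named here.

Measured so far:
compound 1 `Cc1c(Nc2nc(N)c3c(C#N)c(N4CCC[C@H]4C)n(C)c3n2)cnn1C` — 3 nM
compound 2 `Cn1c(NCc2ccccc2)c(C#N)c2c(N)ncnc21` — 243 nM

In an assay on isolated protein for binding affinity to Leucine-rich repeat serine/threonine-protein kinase 2 variant G2019S (Homo sapiens), read by TR-FRET and LanthaScreen, with a stated time of 2 h (on this read-out higher numbers stand for weaker inhibition and lower numbers for stronger inhibition), compound 1 gives the lowest of the two numbers; compound 2 sits at a markedly higher number, well beyond the scatter. Compound 3 `C[C@@H]1CCCN1c1c(C#N)c2c(N)nc(N)nc2n1C` is not yet measured. It differs from compound 1 by hydrogen in place of 1,5-dimethyl-1H-pyrazol-4-yl on a nitrogen on an aromatic ring. Going by the values given here, no step between two measured compounds follows this change, so the expectation rests only on the change itself. A sizeable loss is expected, since the leaving group carries the hydrogen-bond acceptors counted for it. The step from compound 1 to compound 3 is estimated as a 50-fold higher number from compound 1 to compound 3 (1.70 log units; beyond the scatter), with compound 3 expected near 150 nM (range 30 nM to 800 nM).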

Compound 3, inhibition constant: 13 nM
Compound 3: middle estimate off by 12-fold (1.06 log units), on the high side; the whole stated range lies above it.
By their numbers in this assay, from the lowest: compound 1; then compound 3; then compound 2.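

With hydrogen in place of 1,5-dimethyl-1H-pyrazol-4-yl on a nitrogen on an aromatic ring, this assay shows a 4.3-fold higher number from compound 1 to compound 3 (0.64 log units; beyond the scatter), a modest step. This position therefore contributes to the lower number of compound 1, but compound 3 still gives 13 nM with the plain amino group, so the 1,5-dimethyl-1H-pyrazol-4-yl group is not needed for a low number. No available evidence bears on the size of this step. From the compounds shown here alone, how a phenyl ring, an acetyl group or a small alkyl chain on this nitrogen would compare remains open.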